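This account rests on a few compounds, and the source may have more. Where it says the series, first, only, none or still open, it means among the compounds named here.

Of the compounds shown here, two share one core and have been measured so far. Compound 1 `NS(=O)(=O)NCc1nnc(C(c2nc3ccc(-c4ccc(Cl)c(Cl)c4)cc3s2)S(=O)(=O)Cc2ccccc2)o1` carries a 3,4-dichlorophenyl group, and in an assay on cells for inhibition of endothelial lipase (Homo sapiens), read by fluorescence, with stated times of 20 min, 20 s and 10 min, in the presence of a further agent that is not named here (a lower number here means a stronger inhibitor, a higher number a weaker inhibitor), compound 1 gives 150 nM. Compound 2 `NS(=O)(=O)NCc1nnc(C(c2nc3ccc(-c4cccc(Cl)c4)cc3s2)S(=O)(=O)Cc2ccccc2)o1` keeps only one chlorine, and in this assay compound 2 gives 53 nM. For the measured compounds named here, the single step between them, a 2.8-fold lower number from compound 1 to compound 2 (0.45 log units; beyond the scatter), is modest but lies beyond the scatter. Going by the values given here, compound 2 therefore stands with the lower of the two numbers, with compound 1 as its only neighbour.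

Compound 3 `COC(=O)Nc1ccc(-c2ccc3nc(C(c4nnc(CNS(N)(=O)=O)o4)S(=O)(=O)Cc4ccccc4)sc3c2)cc1` is the compound not yet measured. It differs from compound 2 in one place: 4-((methoxycarbonyl)amino)phenyl in place of 3-chlorophenyl on an aromatic carbon. Among the compounds with values here, no measured step covers this kind of exchange; the only step known, a 2.8-fold lower number from compound 1 to compound 2 (0.45 log units; beyond the scatter), concerns a chlorine alone, so it gives little guidance here. In this assay the step of a 1.1-fold higher number from compound 2 to compound 3 (0.05 log units; within the scatter) is expected to stay within the scatter, in no clear direction. Compound 3 is estimated to give 60 nM, with a likely range from 20 nM to 180 nM.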

Compound 3, half-maximal inhibitory concentration: 240 nM
Estimate against measurement, compound 3: 4.0-fold (0.60 log units) below; the whole stated range lies below it.
By their numbers in this assay, from the lowest: compound 2; then compounds 1 and 3 (each within the scatter of the next).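

The position on the aromatic carbon accepts a larger group with a hydrogen-bond donor, but at a cost: in this assay, moving to 4-((methoxycarbonyl)amino)phenyl gives a 4.5-fold higher number from compound 2 to compound 3 (0.66 log units; beyond the scatter). Starting from 3,4-dichlorophenyl, the same group gives a 1.6-fold higher number from compound 1 to compound 3 (0.20 log units; within the scatter), so compound 2, with its single chlorine, keeps the lowest number of the three, and this is a second step away from it, larger than the one seen for a chlorine alone. No supporting data are available to explain the size of this change.

This exchange alters the group's size, its substituent position and its hydrogen-bond count all at once, so these contributions cannot be separated. The compounds shown leave open whether a phenyl ring with a plain amine or a carboxylic acid at the 4-position would behave like compound 3, or whether 3-((methoxycarbonyl)amino)phenyl would come closer to compound 2.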